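Fluoro for methoxy on the aryl ring of a succinimide amide

This account rests on a few compounds, and the source may have more. Where it says the series, first, only, none or still open, it means among the compounds named here.

Measured compounds in this series:
compound 1, `COc1cccc(N2CCN(C(=O)C(C)N3C(=O)CCC3=O)CC2)c1`, 0%
compound 2, `COCC(C(=O)N1CCN(c2cccc(C(F)(F)F)c2)CC1)N1C(=O)CCC1=O`, 100%
compound 3, `CCC(C(=O)N1CCN(c2cccc(OC)c2)CC1)N1C(=O)CCC1=O`, 0%

In a functional assay on the whole organism (strain Swiss) with Mus musculus as the target, in the maximal electroshock model, with a stated time of 2 h, at a dose of 300 mg/kg by the intraperitoneal route (a higher number here means a stronger effect of the compound at the dose given, a lower number a weaker effect), compound 1 gives 0%, level with compound 3 and the lowest of the three numbers, while compound 2 stands far higher. Compound 4, `CC(C(=O)N1CCN(c2cccc(F)c2)CC1)N1C(=O)CCC1=O`, is not yet measured. It differs from compound 1 by fluoro in place of methoxy on an aromatic carbon. Among the compounds with values here, no measured step touches the aryl substituent: the only single-place step, no change at the digits printed from compound 1 to compound 3 (within the scatter), concerns the chain carbon. Within the data shown here, compound 2 differs from compound 1 in two places, so its high value shows only that a different aryl group can coincide with strong activity. For compound 4 the step of a number 25 percentage points higher from compound 1 to compound 4 (beyond the scatter) is therefore a guess, and compound 4 is estimated at 25% (range 0% to 100%).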

Compound 4, a percentage reported as activity, at one dose (the size of the read-out at that dose, not a potency): 100%
Compound 4: middle estimate off by 75 percentage points, on the low side; measured number inside the range.
By their numbers in this assay, from the lowest: compounds 1 and 3 (each within the scatter of the next); then compounds 2 and 4 (each within the scatter of the next).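

Within the data shown here, the change from 3-methoxyphenyl to 3-fluorophenyl gives a number 100 percentage points higher from compound 1 to compound 4 (beyond the scatter) in this assay, the first single-place step at this aromatic carbon. Unlike the step on the chain carbon, no change at the digits printed from compound 1 to compound 3 (within the scatter), it shows that this one substituent can by itself separate a silent compound from an active one on the shared core. Nothing available here accounts for the size of this step. Going by these compounds, whether chloro or an amine at this aromatic carbon would match fluoro remains open, as does whether fluoro would have the same effect with the chain of compound 3.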